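Methyl on the Aniline Ring of a Trimethoxyphenyl Enaminone

This account rests on a few compounds, and the source may have more. Where it says the series, first, only, none or still open, it means among the compounds named here.

The measured compounds and their values:
compound 1 `COc1cc(OC)c2sc(-c3ccc(N/C=C\C(=O)c4cc(OC)c(OC)c(OC)c4)cc3)nc2c1` 15800 nM
compound 2 `COc1cc(OC)c2sc(-c3ccc(N/C=C\C(=O)c4cc(OC)c(OC)c(OC)c4Br)cc3)nc2c1` 16100 nM
compound 3 `COc1cc(OC)c2sc(-c3ccc(N/C=C\C(=O)c4cc(OC)c(OC)c([N+](=O)[O-])c4)cc3)nc2c1` 3060 nM

In a functional assay on MDA-MB-231 cells (Homo sapiens) for antiproliferative activity, read by sulforhodamine B assay, with a stated time of 48 h (on this read-out higher numbers stand for weaker inhibition and lower numbers for stronger inhibition), compound 1 stands second highest of the three numbers. Its steps: a 1.0-fold higher number from compound 1 to compound 2 (0.01 log units; within the scatter) and a 5.2-fold lower number from compound 1 to compound 3 (0.71 log units; beyond the scatter). Compound 4 `COc1cc(OC)c2sc(-c3ccc(N/C=C\C(=O)c4cc(OC)c(OC)c(OC)c4)c(C)c3)nc2c1` is not yet measured; it differs from compound 1 by methyl in place of hydrogen on an aromatic carbon. Among the measured compounds shown here, neither measured step touches this ring, so no step bears directly on the change. For the measured compounds named here, the only comparable step, a 1.0-fold higher number from compound 1 to compound 2 (0.01 log units; within the scatter), shows a small added group on the other aromatic ring leaving the number where it was. The step from compound 1 to compound 4 in this assay is therefore expected to be about a 1.1-fold lower number from compound 1 to compound 4 (0.02 log units; within the scatter). For compound 4 the expected value is 15000 nM, within the range 6000 nM to 40000 nM.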

Compound 4, half-maximal inhibitory concentration: 13800 nM
The estimate for compound 4 lay 1.1-fold (0.04 log units) above the measured number, and the stated range covers the measured number.
By their numbers in this assay, from the lowest: compound 3; then compounds 4, 1 and 2 (each within the scatter of the next).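

In this assay, among the compounds shown here, methyl in place of hydrogen gives a 1.1-fold lower number from compound 1 to compound 4 (0.06 log units; within the scatter) and so provides the first reading on this six-membered aromatic ring of carbon only. At this position, ortho to a large group, one added methyl leaves the number within the scatter of compound 1. Nothing available explains this result. On these data alone, what remains open is whether this position stays as undemanding with other groups, such as an amine, a carboxylic acid or a longer chain, since a single methyl cannot show that.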